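A few compounds are considered here, and "the series" means these few. Any claim that something is new, unique, unknown or untested is made for them only; others in the source may bear on it.

In a functional assay on MKN-45 cells (Homo sapiens) for cytotoxicity, read by MTT assay, with a stated time of 72 h (a lower number here means a stronger inhibitor, a higher number a weaker inhibitor), compound 3 `CN(C)CCn1cnnc1-c1cc(Oc2ccc(NC(=O)N/N=C/c3ccc(F)cc3F)cc2F)ccn1` gives 810 nM, the lowest of the three numbers measured; compound 1 `CN(C)CCn1cnnc1-c1cc(Oc2ccc(NC(=O)N/N=C/c3ccc(F)cc3)cc2F)ccn1` gives 1030 nM, and compound 2 `COc1ccc(/C=N/NC(=O)Nc2ccc(Oc3ccnc(-c4nncn4CCN(C)C)c3)c(F)c2)c(OC)c1OC` gives 2020 nM. The step of a 1.3-fold lower number from compound 1 to compound 3 (0.10 log units; within the scatter) lies within the scatter, while a 2.5-fold lower number from compound 2 to compound 3 (0.40 log units; beyond the scatter) is a modest step beyond it. Compound 4 `CN(C)CCn1cnnc1-c1cc(Oc2ccc(NC(=O)N/N=C/c3ccccc3)cc2F)ccn1` differs from compound 3 by phenyl in place of 2,4-difluorophenyl on a carbon with a double bond to nitrogen. Within the data shown here, the only step that bears on it is the step from compound 1 to compound 3, which added a fluoro without a change beyond the scatter; removing both fluorines is therefore expected to give at most a small rise in this assay, likely within the scatter. Compound 4 is expected to give 1100 nM in this assay, between 500 nM and 2500 nM, a step of a 1.4-fold higher number from compound 3 to compound 4 (0.13 log units; within the scatter).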

Compound 4, half-maximal inhibitory concentration: 2730 nM
Compound 4: the middle estimate sits 2.5-fold (0.39 log units) below what was measured; the whole stated range lies below it.
By their numbers in this assay, from the lowest: compounds 3, 1, 2 and 4 (each within the scatter of the next, the first and the last beyond it).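

In this assay, among these compounds, the fluorines at this position count: phenyl in place of 2,4-difluorophenyl gives a 3.4-fold higher number from compound 3 to compound 4 (0.53 log units; beyond the scatter), and hydrogen in place of fluoro gives a 2.7-fold higher number from compound 1 to compound 4 (0.42 log units; beyond the scatter), so losing the one fluoro moves the number beyond the scatter, though gaining a second one did not. Phenyl in place of 2,3,4-trimethoxyphenyl gives a 1.4-fold higher number from compound 2 to compound 4 (0.13 log units; within the scatter), so these two rings cannot be told apart here. Nothing available gives a reason for these steps.

The compounds shown leave open whether chloro, nitrile or an amine on this ring would match compound 1 and compound 3.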